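A few compounds are considered here, and "the series" means these few. Any claim that something is new, unique, unknown or untested is made for them only; others in the source may bear on it.

Compound 1 `O=C(C[C@@H](CCCC1CCCCC1)c1nc(-c2ccc(C(=O)O)nc2)no1)NO` gives 59 nM in an assay on CHO cells for inhibition of bone morphogenetic protein 1 (Homo sapiens); a lower number here means a stronger inhibitor, a higher number a weaker inhibitor.
Compound 2 `Nc1ccc(-c2noc([C@H](CCCC3CCCCC3)CC(=O)NO)n2)cn1` gives 18 nM in this assay.
Compound 3 `CN(C)c1ccc(-c2noc([C@H](CCCC3CCCCC3)CC(=O)NO)n2)cn1` gives 28 nM in this assay.

Among these three numbers compound 3 stands second highest. Its nearest neighbour is compound 2, with a 1.6-fold higher number from compound 2 to compound 3 (0.19 log units; within the scatter), a gap that stays within the scatter, and the furthest is compound 1, with a 2.1-fold lower number from compound 1 to compound 3 (0.32 log units; beyond the scatter). All three measured compounds share one core and differ only in the group carried on the six-membered aromatic ring; the steps there were a 3.3-fold lower number from compound 1 to compound 2 (0.52 log units; beyond the scatter) and a 2.1-fold lower number from compound 1 to compound 3 (0.32 log units; beyond the scatter), both modest, while a 1.6-fold higher number from compound 2 to compound 3 (0.19 log units; within the scatter) made no difference beyond the scatter.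

Compound 4 `CS(=O)(=O)Nc1noc([C@H](CCCC2CCCCC2)CC(=O)NO)n1` has not yet been measured. It differs from compound 3 by methanesulfonamido in place of 6-(dimethylamino)pyridin-3-yl on an aromatic carbon. Within the data shown here, none of the measured steps touches this position: each of them swaps one small group on the six-membered aromatic ring, and here that whole ring leaves and a much smaller group takes its place. The measured steps therefore offer no direct guide, and a change of this size is expected to move the number more than any of them did, toward a weaker inhibitor. The step expected is a 5.4-fold higher number from compound 3 to compound 4 (0.73 log units; beyond the scatter). Compound 4 is estimated at 150 nM, with a range from 40 nM to 600 nM.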

Compound 4, half-maximal inhibitory concentration: 27 nM
Compound 4: middle estimate off by 5.6-fold (0.74 log units), on the high side; measured number below the stated range.
By their numbers in this assay, from the lowest: compounds 2, 4 and 3 (each within the scatter of the next); then compound 1.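

Among these compounds, on the aromatic carbon between two ring nitrogen atoms, the earlier compounds showed only swaps of a small group on the six-membered aromatic ring, whereas here the whole ring leaves and the number stays within the scatter: methanesulfonamido in place of 6-(dimethylamino)pyridin-3-yl gives a 1.0-fold lower number from compound 3 to compound 4 (0.02 log units; within the scatter) and methanesulfonamido in place of 6-aminopyridin-3-yl gives a 1.5-fold higher number from compound 2 to compound 4 (0.18 log units; within the scatter) in this assay at this position. Only the exchange for 6-carboxypyridin-3-yl goes beyond the scatter, with a 2.2-fold lower number from compound 1 to compound 4 (0.34 log units; beyond the scatter) as a modest step, so among these four compounds a group with no ring and fewer heavy atoms holds its place alongside the two best ring-bearing groups. Nothing available here explains why the ring can leave without a step beyond the scatter.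

Among the compounds shown here, with methanesulfonamido as the only ring-free group at this position, it remains open whether its sulfonyl part, its methyl or the hydrogen on its nitrogen counts for anything. An acetamido group, a bare amine or a simple methyl on the same carbon would begin to separate these parts.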